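The source may report more compounds than this note shows. Statements on the series, on what has been measured and on what is new or still open speak of the compounds shown alone.

Among the compounds with values here, in an ADME assay on L02 cells (Homo sapiens) for cytotoxicity, read by MTT assay, with a stated time of 48 h (a lower number here means a stronger inhibitor, a higher number a weaker inhibitor), compound 2 `C#CCNC(=O)c1ccc(C(CC)(CC)c2ccc(OCC(O)C(C)(C)C)c(C)c2)n1CC` gives 4400 nM, the higher of the two numbers so far, while compound 1 `CCn1c(C(=O)NCCCN(C)C)ccc1C(CC)(CC)c1ccc(OCC(O)C(C)(C)C)c(C)c1` gives 470 nM. Compound 3 `CCn1c(C(=O)NCCN)ccc1C(CC)(CC)c1ccc(OCC(O)C(C)(C)C)c(C)c1` changes one group of compound 2: aminomethyl in place of ethynyl on a saturated chain carbon bound to an amide-type nitrogen. In words, aminomethyl stands in place of ethynyl on a saturated chain carbon bound to an amide-type nitrogen, or propargyl to 2-aminoethyl when cut one bond further out. Within the data shown here, one measured step bears on this place: a 9.4-fold higher number from compound 1 to compound 2 (0.97 log units; beyond the scatter), where ethynyl replaced 2-(dimethylamino)ethyl, a change beyond the scatter. Compound 3 also loses ethynyl, so a move to a lower number in this assay is expected, in the reverse direction of that step. A single step cannot fix the size, so only part of it is expected to return. The expected change is a 4.4-fold lower number from compound 2 to compound 3 (0.64 log units; beyond the scatter). For compound 3 the estimate is 1000 nM, with an expected range of 350 nM to 3000 nM.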

Compound 3, half-maximal inhibitory concentration: 2400 nM
For compound 3 the middle estimate is 2.4-fold (0.38 log units) below the measured one; the measured number falls inside the stated range.
By their numbers in this assay, from the lowest: compound 1; then compounds 3 and 2 (each within the scatter of the next).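

In this assay, aminomethyl in place of ethynyl on a saturated chain carbon bound to an amide-type nitrogen gives a 1.8-fold lower number from compound 2 to compound 3 (0.26 log units; within the scatter) and so does not separate these two groups, although aminomethyl brings a hydrogen-bond donor and acceptor that ethynyl lacks. Amino in place of (dimethylamino)methyl gives a 5.1-fold higher number from compound 1 to compound 3 (0.71 log units; beyond the scatter) in the same assay, so an amino group alone does not reproduce the number of compound 1, which stands apart from both other compounds. No measurement at hand gives a reason for either result.

As far as these compounds go, it remains open whether the chain length or the dimethylamino group carries the step from compound 1, and a 3-aminopropyl or 2-(dimethylamino)ethyl group on the amide-type nitrogen would separate the two. From the compounds shown here alone, the effect of a carboxylic acid in place of the amino group also remains open.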